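Changing the dichlorophenyl pattern on a glycine transporter inhibitor

The source may report more compounds than this note shows. Statements on the series, on what has been measured and on what is new or still open speak of the compounds shown alone.

Measured compounds:
Compound 1 `CC(C)S(=O)(=O)N1C[C@@H]2[C@H](C1)[C@@]2(CNC(=O)c1ccc(Cl)cc1Cl)CC1CC1`: 3400 nM
Compound 2 `Cn1cnc(S(=O)(=O)N2C[C@@H]3[C@H](C2)[C@@]3(CNC(=O)c2cc(Cl)cc(Cl)c2)CC2CC2)c1`: 100 nM
Compound 3 `O=C(NC[C@]1(CC2CC2)[C@@H]2CN(S(=O)(=O)CC3CC3)C[C@@H]21)c1ccc(Cl)cc1Cl`: 230 nM

In an assay on isolated protein for inhibition of sodium- and chloride-dependent glycine transporter 1 (Homo sapiens) (on this read-out higher numbers stand for weaker inhibition and lower numbers for stronger inhibition), compound 2 gives the lowest number of the three, with compound 3 next and compound 1 furthest away. The measured step of a 15-fold lower number from compound 1 to compound 3 (1.17 log units; beyond the scatter) concerns the sulfonyl side only and says nothing about the aromatic amide. Compound 4 `Cn1cnc(S(=O)(=O)N2C[C@@H]3[C@H](C2)[C@@]3(CNC(=O)c2ccc(Cl)cc2Cl)CC2CC2)c1` keeps the sulfonyl group of compound 2 and differs only by 2,4-dichlorophenyl in place of 3,5-dichlorophenyl on a carbonyl carbon. Among the compounds with values here, no measured pair shows this exchange on its own, so the direction is uncertain; compounds 1 and 3 show that the 2,4-dichlorophenyl arrangement can still give strong or weak inhibition depending on the rest. Compound 4 is therefore estimated at 220 nM, between 50 nM and 900 nM. This estimate corresponds to an expected 2.2-fold higher number from compound 2 to compound 4 (0.34 log units; beyond the scatter).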

Compound 4, half-maximal inhibitory concentration: 4 nM
Beside the measured number, compound 4's estimate is 55-fold (1.74 log units) above it, and the stated range ends above it.
By their numbers in this assay, from the lowest: compound 4; then compound 2; then compound 3; then compound 1.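

In this assay, the step of a 25-fold lower number from compound 2 to compound 4 (1.40 log units; beyond the scatter) comes from the 2,4-dichlorophenyl pattern replacing 3,5-dichlorophenyl on a carbonyl carbon, so the arrangement of the same atoms matters greatly here. With 2,4-dichlorophenyl held fixed, the sulfonyl group also matters: the steps of a 58-fold lower number from compound 3 to compound 4 (1.76 log units; beyond the scatter) and an 850-fold lower number from compound 1 to compound 4 (2.93 log units; beyond the scatter) both come from introducing 1-methyl-1H-imidazol-4-yl. Nothing available explains these differences. Still open, from the compounds shown here alone, is whether the chlorine exchange acts as strongly with isopropyl or cyclopropylmethyl on the sulfonyl sulfur, and how a 2,4-difluorophenyl or 2,4-dimethylphenyl group would compare.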